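Third methyl on the arylhydrazone of compound 2

The compounds below may be only part of what the source reports. "The series", "measured", "known", "first", "only" and "open" are said of these compounds alone.

Compound 1 `CC1CCC(=NNc2ccccc2)c2ncc(C(=O)O)c(=O)n21` gives 1.2 umol/kg in a functional assay on the whole organism with Rattus norvegicus as the target; on this read-out lower numbers stand for an effect already at smaller amounts and higher numbers for an effect only at larger amounts of compound. Compound 2 `Cc1ccc(NN=C2CCC(C)n3c2ncc(C(=O)O)c3=O)cc1C` is known in this assay only as a limit, not a number: compound 2 gives > 100 umol/kg, the limit named in the limit of > 100 umol/kg in this assay, at which 1 of the 3 values shown sits. Compound 3 `Cc1cc(C)cc(NN=C2CCC(C)n3c2ncc(C(=O)O)c3=O)c1` likewise reaches only a limit, compound 3 giving > 320 umol/kg as in the limit of > 320 umol/kg in this assay, at which 1 of the 3 values shown sits. So compound 2 cannot be placed on a scale among the numbers at hand; it stands with one other value that is also a limit, and the two limits together leave a step that the two limits leave unreadable from compound 2 to compound 3 without a size.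

Compound 4 `Cc1cc(C)c(NN=C2CCC(C)n3c2ncc(C(=O)O)c3=O)cc1C` differs from compound 2 by methyl in place of hydrogen on an aromatic carbon. Among the measured compounds shown here, the steps that bear on this change are an at least 83-fold higher number from compound 1 to compound 2 (1.92 log units; beyond the scatter) and an at least 260-fold higher number from compound 1 to compound 3 (2.42 log units; beyond the scatter), both large and both toward higher doses on adding methyl groups to the phenyl. For the measured compounds named here, a further methyl on the same ring is therefore expected to leave the read-out at or beyond a limit rather than recover activity; no step points the other way. Compound 4 is estimated at 300 umol/kg, within 100 umol/kg to 1000 umol/kg, which means an expected step that the limit leaves unreadable from compound 2 to compound 4.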

Compound 4, dose for 50% inhibition: 320 umol/kg
Estimate against measurement, compound 4: 1.1-fold (0.03 log units) below; low and high end bracket the measured number.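

In this assay, among the compounds shown here, compound 2 is known only as a limit, > 100 umol/kg, and no step from it to compound 4 can be read. The compounds shown leave open whether methyl in place of hydrogen on this aromatic carbon shifts the dose at all, and in which direction.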